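Notes on the step from compound 2 to compound 3

A few compounds are considered here, and "the series" means these few. Any claim that something is new, unique, unknown or untested is made for them only; others in the source may bear on it.

Measured so far in a functional assay on SK-OV-3 cells (Homo sapiens) for cytotoxicity; on this read-out higher numbers stand for weaker inhibition of growth and lower numbers for stronger inhibition of growth (all values are numbers, not limits):
- compound 1 `CSc1ccc(C2=C(c3ccc(O)c(O)c3)C(=O)N3CCCC3C2)cc1` gives 80000 nM
- compound 2 `CSc1ccc(C2=C(c3ccc(F)cc3)C(=O)N3CCCC3C2)cc1` gives 30000 nM

Compound 2 holds the lower of the two numbers. Compound 3 `CSc1ccc(C2=C(c3ccc(SC)cc3)C(=O)N3CCCC3C2)cc1` has methylsulfanyl in place of fluoro on an aromatic carbon and remains unmeasured. Among the compounds with values here, one measured step touches this aromatic ring, the modest 2.7-fold lower number from compound 1 to compound 2 (0.43 log units; beyond the scatter), but it is a different replacement and gives only weak guidance. No step beyond the scatter is therefore expected in this assay, and the expected change is a 1.2-fold lower number from compound 2 to compound 3 (0.08 log units; within the scatter) overall. For compound 3 the estimated value is 25000 nM (expected range 9000 nM to 70000 nM) in this read-out.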

Compound 3, concentration for 50% growth inhibition: 2000 nM
Compound 3: middle estimate off by 13-fold (1.10 log units), on the high side; the whole stated range lies above it.
By their numbers in this assay, from the lowest: compound 3; then compound 2; then compound 1.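

In this assay, this aromatic position proves far more sensitive than the earlier pair showed: methylsulfanyl in place of fluoro gives a large step (a 15-fold lower number from compound 2 to compound 3 (1.18 log units; beyond the scatter)), against the modest one seen before (a 2.7-fold lower number from compound 1 to compound 2 (0.43 log units; beyond the scatter)). Against 3,4-dihydroxyphenyl, 4-(methylsulfanyl)phenyl gives a still wider step (a 40-fold lower number from compound 1 to compound 3 (1.60 log units; beyond the scatter)), leaving compound 3 with the lowest number of the three. No measurement shown here accounts for this gain.

Open, as far as these compounds go, is whether the gain follows the sulfur atom: methoxy or ethylsulfanyl on the same aromatic carbon would test this. Also open, from the compounds shown here alone, is whether an amine is tolerated there.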